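Replacing a Chlorine-Bearing Group on a Shared Core

The compounds below may be only part of what the source reports. "The series", "measured", "known", "first", "only" and "open" are said of these compounds alone.

Three compounds share one core and differ only in a small group on a carbonyl carbon. In a functional assay for inhibition, with Homo sapiens as the target (on this read-out higher numbers stand for an effect only at larger amounts of compound and lower numbers for an effect already at smaller amounts), compound 1 `CCC(=O)Nc1ccc(C2=NNC(=O)CC2)cc1` gives 0.64 ug/mL. In the same test compound 2 `CCC(Cl)C(=O)Nc1ccc(C2=NNC(=O)CC2)cc1` gives 1.47 ug/mL, the higher of the two numbers, so it needs the larger amount to show its effect. The next compound to be measured is compound 3 `CC(C)NCC(=O)Nc1ccc(C2=NNC(=O)CC2)cc1`. Its structure differs from compound 2 as follows: a group of 5 heavy atoms (4 carbon, 1 nitrogen; no ring) in place of a group of 4 heavy atoms (3 carbon, 1 chlorine; no ring), on a carbonyl carbon. The entering group is (isopropylamino)methyl.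

Going by the values given here, only one measured step bears on this change, and it offers limited guidance. It is a 2.3-fold higher number from compound 1 to compound 2 (0.36 log units; beyond the scatter), a modest difference that lies beyond the scatter. Among the compounds with values here, that step shows that changing this group can move the number, but no measured compound carries the entering group, so the data do not indicate a direction. The expected result is therefore no change beyond the scatter, with an estimated 1.2-fold lower number from compound 2 to compound 3 (0.09 log units; within the scatter). For compound 3 the estimated value in this assay is 1.2 ug/mL, with an expected range from 0.35 ug/mL to 4 ug/mL.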

Compound 3, half-maximal effective concentration: about 46.4 ug/mL
Beside the measured number, compound 3's estimate is 39-fold (1.59 log units) below it; measured number outside the range, above it.
By their numbers in this assay, from the lowest: compound 1; then compound 2; then compound 3.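

In this assay, the group on this carbonyl carbon proves able to move the number much further than the earlier pair showed: putting (isopropylamino)methyl in place of the chlorine-bearing group gives a 32-fold higher number from compound 2 to compound 3 (1.50 log units; beyond the scatter) and, set against the smaller group at the same place, the change gives a 73-fold higher number from compound 1 to compound 3 (1.86 log units; beyond the scatter) as well. Going by these compounds alone, both of these steps are large, while the only earlier step, a 2.3-fold higher number from compound 1 to compound 2 (0.36 log units; beyond the scatter), was modest, so a larger effect at this position came to light only with the entering group. Compound 3 now needs the largest amount of the three to show its effect, but no accompanying data explain the rise in its number.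

The compounds shown leave open whether the nitrogen of the entering group, its isopropyl part or the whole group goes with the higher number, since all of these enter together in one change. A plain aminomethyl group, a longer carbon chain without nitrogen or a carboxylic acid at this place would help to separate these parts and show how far the trend holds.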